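This account rests on a few compounds, and the source may have more. Where it says the series, first, only, none or still open, it means among the compounds named here.

Measured so far:
- compound 1 `O=C1C[C@H](NC(=O)[C@@H]2COC[C@@H]3CCCC[C@H](NC(=O)c4nccc5ccccc45)C(=O)N32)C(O)O1` gives 101 nM in a functional assay on THP-1 cells (Homo sapiens) for inhibition; a lower number here means a stronger inhibitor, a higher number a weaker inhibitor
- compound 2 `O=C1C[C@H](NC(=O)[C@@H]2CN(C(=O)Nc3ccccc3)C[C@@H]3CCCC[C@H](NC(=O)c4ccccc4)C(=O)N32)C(O)O1` gives 1690 nM in this assay
- compound 3 `O=C1C[C@H](NC(=O)[C@@H]2COC[C@@H]3C/C=C\C[C@H](NC(=O)c4ccc5ccccc5c4)C(=O)N32)C(O)O1` gives 62 nM in this assay

Compound 2 has the highest number of the three in this assay; the gap to compound 1 and the gap to compound 3 both lie beyond the scatter, so compound 2 is the weakest inhibitor of the set as measured. For the measured compounds named here, compound 1 and compound 3 differ from compound 2 in more than one place, so no single step between measured compounds is available.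

Compound 4 `O=C1C[C@H](NC(=O)[C@@H]2CNC[C@@H]3CCCC[C@H](NC(=O)c4ccccc4)C(=O)N32)C(O)O1` is derived from compound 2 by one change: hydrogen in place of phenylcarbamoyl on an amine nitrogen in a ring. The phenylcarbamoyl group is removed from the amine nitrogen in the ring, leaving a hydrogen there. Going by the values given here, no measured pair shows what this change does on its own. The step of a 1.7-fold lower number from compound 2 to compound 4 (0.23 log units; within the scatter) is expected to be small, most likely within the scatter, with a lean toward a somewhat lower number. For compound 4 the expected value in this assay is 1000 nM, within a range of 250 nM to 4000 nM.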

Compound 4, half-maximal inhibitory concentration: 245 nM
Compound 4: the middle estimate sits 4.1-fold (0.61 log units) above what was measured; the whole stated range lies above it.
By their numbers in this assay, from the lowest: compounds 3 and 1 (each within the scatter of the next); then compound 4; then compound 2.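

In this assay, for the compounds shown here, the step from a phenylcarbamoyl group to hydrogen on the amine nitrogen in a ring is a 6.9-fold lower number from compound 2 to compound 4 (0.84 log units; beyond the scatter), the first single-change reading at this position. On this core, phenylcarbamoyl at this nitrogen therefore goes with weaker inhibition, and the nitrogen bearing only hydrogen is tolerated. Nothing available accounts for the size of this step, so it stands as an observation only.

As far as these compounds go, what a small group on the same nitrogen, such as methyl or acetyl, would give remains open, and with it whether any substituent here can match or improve on hydrogen. From the compounds shown here alone, compound 1 and compound 3 differ from compound 4 in more than one place, so whether the step carries over to other amide groups on the core also remains open.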